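Removing the Ring Methyl from Compound 1

The source may report more compounds than this note shows. Statements on the series, on what has been measured and on what is new or still open speak of the compounds shown alone.

Compound 1 `CCOC(=O)c1cnc(C(F)(F)F)nc1NN1C(=O)C=C(C)C1=O` stands second highest of three numbers: in a functional assay on Jurkat cells for inhibition of nuclear factor NF-kappa-B complex (Homo sapiens) (on this read-out lower numbers stand for stronger inhibition and higher numbers for weaker inhibition), compound 1 gives 1000 nM, compound 2 `CCOC(=O)c1cnc(-c2ccsc2)nc1NN1C(=O)C=C(C)C1=O` gives 100 nM, and compound 3 `CCOC(=O)c1cnc(C(F)(F)F)nc1NN1C(=O)C(C)=C(C)C1=O` gives 10000 nM. The measured steps are a 10-fold lower number from compound 1 to compound 2 (1.00 log units; beyond the scatter) and a 10-fold higher number from compound 1 to compound 3 (1.00 log units; beyond the scatter). Compound 4 `CCOC(=O)c1cnc(C(F)(F)F)nc1NN1C(=O)C=CC1=O` differs from compound 1 by hydrogen in place of methyl on a double-bonded ring carbon. Among the compounds with values here, the step that bears on this change is the one from compound 1 to compound 3, in which a methyl entered on a double-bonded ring carbon and the number rose by a modest amount; taking away the methyl that compound 1 already carries runs the opposite way, so a lower number is expected, though the two changes need not mirror each other exactly. Compound 4 is therefore expected to give 500 nM, between 150 nM and 3000 nM, a step of a 2.0-fold lower number from compound 1 to compound 4 (0.30 log units; within the scatter).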

Compound 4, half-maximal inhibitory concentration: 10000 nM
Compound 4: middle estimate off by 20-fold (1.30 log units), on the low side; measured number outside the range, above it.
By their numbers in this assay, from the lowest: compound 2; then compound 1; then compounds 3 and 4 (each within the scatter of the next).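

In this assay, taking the methyl off the double-bonded ring carbon gives a 10-fold higher number from compound 1 to compound 4 (1.00 log units; beyond the scatter), the same direction as the step on adding a methyl, a 10-fold higher number from compound 1 to compound 3 (1.00 log units; beyond the scatter). Among the compounds shown, then, both changes to the methyl count on this ring raise the number from compound 1, so removal does not mirror addition. Nothing shown accounts for this.

As far as these compounds go, it remains open whether an ethyl or a chlorine on this ring carbon would keep the number of compound 1. Also open, from the compounds shown here alone, is whether removing the methyl from compound 2, with its thiophen-3-yl, would raise the number likewise.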